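The compounds below may be only part of what the source reports. "The series", "measured", "known", "first", "only" and "open" are said of these compounds alone.

Measured so far:
compound 1 `CCCCCCCCn1cc(/C=C/C(=O)c2ccc(NC(=O)CN3CCN(c4ccccc4F)CC3)cc2)nn1` — 60300 nM
compound 2 `CCCCCCCCCCn1cc(/C=C/C(=O)c2ccc(NC(=O)CN3CCN(C(=O)OC(C)(C)C)CC3)cc2)nn1` — 77800 nM
compound 3 `O=C(CBr)Nc1ccc(C(=O)/C=C/c2cn(Cc3ccc(Br)cc3)nn2)cc1` — 8300 nM

In a functional assay on SK-N-SH cells (Homo sapiens) for inhibition, read by MTT assay (on this read-out lower numbers stand for stronger inhibition and higher numbers for weaker inhibition), compound 3 gives the lowest of the three numbers; its gaps to compound 1 and to compound 2 both lie beyond the scatter, so compound 3 counts as the most active of those measured. Compound 4 `CCCCCCCCn1cc(/C=C/C(=O)c2ccc(NC(=O)CBr)cc2)nn1` is not yet measured. It differs from compound 3 by heptyl in place of 4-bromophenyl on a saturated chain carbon bound to an aromatic nitrogen; the amide part of compound 3 is kept unchanged. Going by the values given here, compounds 1 and 2 carry a saturated chain at the same place and give high numbers, but their amide part differs too, so no step for this change alone is known. A step from compound 3 to compound 4 of moderate size toward a weaker number is expected, a 1.7-fold higher number from compound 3 to compound 4 (0.23 log units; within the scatter). Compound 4 is estimated at 14000 nM in this assay, within 4500 nM to 45000 nM.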

Compound 4, half-maximal inhibitory concentration: 8460 nM
Compound 4: middle estimate off by 1.7-fold (0.22 log units), on the high side, within the range that was stated.
By their numbers in this assay, from the lowest: compounds 3 and 4 (each within the scatter of the next); then compounds 1 and 2 (each within the scatter of the next).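

In this assay, heptyl in place of 4-bromophenyl on a saturated chain carbon bound to an aromatic nitrogen gives a 1.0-fold higher number from compound 3 to compound 4 (0.01 log units; within the scatter), so an aromatic ring is not required at this place while the bromoacetamide is kept. Compound 4 shares its chain with compound 1, which gives 60300 nM with a different amide part, so the saturated chain alone does not bring the high number. No data here explain why the two groups read alike.

From the compounds shown here alone, whether a chain ending in an amine or a carboxylic acid would hold this level at the same place remains open.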